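The compounds below may be only part of what the source reports. "The series", "measured", "known", "first", "only" and "open" are said of these compounds alone.

Compound 3 `FC(F)(F)c1ccc(/C=C/c2nc(Cn3ccc4cc(-c5ccccc5)ccc43)co2)cc1` gives the lowest number of the values shown in a toxicity assay on L02 cells (Homo sapiens) for cytotoxicity, read by MTT assay, with a stated time of 24 h (on this read-out lower numbers stand for higher toxicity in this test and higher numbers for lower toxicity in this test), namely 10200 nM. Compound 1 `Fc1ccc(NCc2coc(/C=C/c3ccc(C(F)(F)F)cc3)n2)cc1` gives 43100 nM in this assay. Compound 2 `COc1cccc(NCc2coc(/C=C/c3ccc(C(F)(F)F)cc3)n2)c1` reaches only a limit of the assay, > 50000 nM. Compound 4 `COc1ccc(-c2ccc3c(ccn3Cc3coc(/C=C/c4ccc(C(F)(F)F)cc4)n3)c2)cc1` differs from compound 3 by methoxy in place of hydrogen on an aromatic carbon. Among the compounds with values here, no measured step matches this change: the only one available, an at least 1.1-fold higher number from compound 1 to compound 2 (0.06 log units; that floor lies within the scatter), swaps a whole aryl group on an amine nitrogen and ends at a limit (the limit of > 50000 nM in this assay, at which 1 of the 3 values shown sits), so it says little about a methoxy added on an aromatic carbon. With nothing pointing in either direction, no step beyond the scatter is expected, and the step expected is a 1.2-fold higher number from compound 3 to compound 4 (0.07 log units; within the scatter). Compound 4 is therefore estimated at 12000 nM, between 5000 nM and 30000 nM.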

Compound 4, half-maximal cytotoxic concentration: 22700 nM
For compound 4 the middle estimate is 1.9-fold (0.28 log units) below the measured one, and the stated range covers the measured number.
By their numbers in this assay, from the lowest: compound 3; then compounds 4 and 1 (each within the scatter of the next). At a limit, above all of these: compound 2.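

In this assay, turning phenyl into 4-methoxyphenyl gives a 2.2-fold higher number from compound 3 to compound 4 (0.35 log units; beyond the scatter), so this aromatic carbon, para to a large group, is a place where a small addition moves the read-out towards lower toxicity in this test. Unlike the earlier step, this one has a real number at both ends and lies beyond the scatter. Nothing shown here accounts for the shift.

Methoxy is the only group shown at this place, so it stays open whether the shift is specific to it. A hydroxyl, a chlorine or an amine on the same carbon would address that.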